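A few compounds are considered here, and "the series" means these few. Any claim that something is new, unique, unknown or untested is made for them only; others in the source may bear on it.

Compound 1 `CCCSc1nc(Cl)c2c(n1)N(Cc1ccccc1)C(C(=O)N1CCN(C)CC1)N2` gives 29800 nM in a functional assay on PC-3 cells (Homo sapiens) for antiproliferative activity, read by MTT assay, with a stated time of 72 h; on this read-out higher numbers stand for weaker inhibition and lower numbers for stronger inhibition.
Compound 2 `CCCSc1nc(Cl)c2c(n1)N(Cc1ccco1)C(C(=O)N1CCN(C)CC1)N2` gives 11400 nM in this assay.
Compound 3 `CCCSc1nc(Cl)c2c(n1)N(Cc1ccccc1)C(C(=O)NCCCc1ccccc1)N2` gives 12700 nM in this assay.

Compound 1 stands with the highest number of the three. Its nearest neighbour is compound 3, reached by a 2.3-fold lower number from compound 1 to compound 3 (0.37 log units; beyond the scatter), and its furthest is compound 2, reached by a 2.6-fold lower number from compound 1 to compound 2 (0.42 log units; beyond the scatter); both steps lie beyond the scatter, so compound 1 is the weakest inhibitor among the measured compounds.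

The new compound is compound 4 `CCCSc1nc(Cl)c2c(n1)N(Cc1ccccc1)C(C(=O)N1CCN(C(=O)OC(C)(C)C)CC1)N2`. It differs from compound 1 in one place: tert-butoxycarbonyl in place of methyl on an amine nitrogen in a ring. Among the measured compounds shown here, no measured step replaces a methyl with a tert-butoxycarbonyl on this ring nitrogen. The step that comes closest is the one at the carbonyl carbon, a 2.3-fold lower number from compound 1 to compound 3 (0.37 log units; beyond the scatter), where a different group on the amide gave a modest lowering; the other step, a 2.6-fold lower number from compound 1 to compound 2 (0.42 log units; beyond the scatter), concerns a distant part of the molecule. Both measured changes to compound 1 lowered the number modestly, so a change of similar or smaller size in the same direction, or none beyond the scatter, is expected. Compound 4 is therefore estimated at 17000 nM, with a range from 6000 nM to 45000 nM, which corresponds to an expected step of a 1.8-fold lower number from compound 1 to compound 4 (0.24 log units; within the scatter).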

Compound 4, half-maximal inhibitory concentration: 47100 nM
Beside the measured number, compound 4's estimate is 2.8-fold (0.44 log units) below it; the measured number lies above the stated range.
By their numbers in this assay, from the lowest: compounds 2 and 3 (each within the scatter of the next); then compounds 1 and 4 (each within the scatter of the next).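

On the amine nitrogen in the ring, tert-butoxycarbonyl in place of methyl gives a 1.6-fold higher number from compound 1 to compound 4 (0.20 log units; within the scatter) in this assay and so stays inside the usual scatter, which means compounds 1 and 4 cannot be told apart on this read-out. Among the compounds shown here, this is the first view of this ring nitrogen, and the exchange brings in far more heavy atoms, a double bond outside aromatic rings and two hydrogen-bond acceptors, yet the number does not shift beyond the scatter, unlike the steps at the other two places, a 2.6-fold lower number from compound 1 to compound 2 (0.42 log units; beyond the scatter) and a 2.3-fold lower number from compound 1 to compound 3 (0.37 log units; beyond the scatter). No supporting measurement is available to explain why this change leaves the result within the scatter.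

From the compounds shown here alone, with only methyl and tert-butoxycarbonyl seen on this nitrogen, it remains open whether a bare ring nitrogen carrying hydrogen, an acetyl group or a benzyl group would also stay within the scatter of compound 1 or would move the number beyond it. Going by these compounds, it is equally open whether tert-butoxycarbonyl would behave the same way with the furan-2-yl group of compound 2 in place of phenyl.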